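Replacing the nitro group of compound 3 with hydroxy

The source may hold more compounds than are shown below. What is called first, only, known or untested is meant among the compounds shown, and "the series" means these compounds.

Compound 1 `COc1ccc(N(C)c2cc(C)nc(C)n2)cc1F`: 632 nM
Compound 2 `COc1ccc(N(C)c2cc(C)nc(C)n2)cc1Cl`: 780 nM
Compound 3 `COc1ccc(N(C)c2cc(C)nc(C)n2)cc1[N+](=O)[O-]`: 3270 nM

In a functional assay on A549 cells (Homo sapiens) for antiproliferative activity, read by MTT assay, with a stated time of 48 h (on this read-out higher numbers stand for weaker inhibition and lower numbers for stronger inhibition), compound 3 has the highest number of the three at 3270 nM, which makes it the weakest inhibitor measured so far. The next structure, compound 4 `COc1ccc(N(C)c2cc(C)nc(C)n2)cc1O`, is still unmeasured. It keeps the shared core and changes one group: hydroxy in place of nitro on an aromatic carbon. This is hydroxy in place of nitro on an aromatic carbon, ortho to a methoxy group.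

All three measured steps concern this same place. Exchanging fluoro for chloro made no real difference: a 1.2-fold higher number from compound 1 to compound 2 (0.09 log units; within the scatter). Nitro gave modest but real losses: a 5.2-fold higher number from compound 1 to compound 3 (0.71 log units; beyond the scatter), and a 4.2-fold higher number from compound 2 to compound 3 (0.62 log units; beyond the scatter). Among the compounds with values here, no compound with a hydroxy group has been measured, so the data cannot speak for that group directly. Within the data shown here, still, nitro is the only group here with a clearly higher number, so removing it should probably give a step of similar modest size towards a lower number, back near compound 1 and compound 2. The expected change is a 5.5-fold lower number from compound 3 to compound 4 (0.74 log units; beyond the scatter). For compound 4 the estimated value is 600 nM, with an expected range from 120 nM to 2500 nM.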

Compound 4, half-maximal inhibitory concentration: 113 nM
For compound 4 the middle estimate is 5.3-fold (0.73 log units) above the measured one; measured number below the stated range.
By their numbers in this assay, from the lowest: compound 4; then compounds 1 and 2 (each within the scatter of the next); then compound 3.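

In this assay hydroxy at this place gives a 29-fold lower number from compound 3 to compound 4 (1.46 log units; beyond the scatter) and also improves on both halogens, with a 6.9-fold lower number from compound 2 to compound 4 (0.84 log units; beyond the scatter) and a 5.6-fold lower number from compound 1 to compound 4 (0.75 log units; beyond the scatter) in the same direction. Until now the only real movement at this position was a loss, seen with nitro, so the values of the fluoro and chloro compounds could have looked like the best this spot allows, and compound 4 shows that they are not. Within the data shown here, compound 4 is the strongest inhibitor of the four, and hydroxy is the only group among them that counts a hydrogen-bond donor, although a single compound can only show that the two coincide.

From the compounds shown here alone, whether that hydrogen matters stays open: a second methoxy group at this place would carry no such hydrogen, while an amine would carry one, and the two would help separate the options. The data shown also offer no measurement that explains why the hydroxy compound stands apart from the other three.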